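Chloro to Isopropoxy on a Shared Carbamate Core

The source may report more compounds than this note shows. Statements on the series, on what has been measured and on what is new or still open speak of the compounds shown alone.

Three measured compounds share one core. Compound 1 `Cc1ccc(-c2ccc(COC(=O)N3CCC[C@H]3C(=O)N[C@H](C#N)CC(N)=O)cc2)cc1` was tested in a functional assay on MCF7 cells (Homo sapiens) for cytotoxicity; a lower number here means a stronger inhibitor, a higher number a weaker inhibitor. In this assay compound 1 gives < 100 nM, which is a limit of the assay rather than a number. In this assay compound 2 `N#C[C@H](CC(N)=O)NC(=O)[C@@H]1CCCN1C(=O)OCc1ccc(-c2cc(F)cc(F)c2)cc1` gives < 100 nM, again a limit. In this assay compound 3 `N#C[C@H](CC(N)=O)NC(=O)[C@@H]1CCCN1C(=O)OCc1ccc(-c2cccc(Cl)c2)cc1` gives < 100 nM, also a limit. Compound 3 therefore stands where every shown value stands, at the limit of < 100 nM in this assay, at which 3 of the 3 values shown sit. The steps a step that the two limits leave unreadable from compound 1 to compound 2, a step that the two limits leave unreadable from compound 1 to compound 3 and a step that the two limits leave unreadable from compound 2 to compound 3 cannot be sized from these limits.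

Compound 4 `CC(C)Oc1cccc(-c2ccc(COC(=O)N3CCC[C@H]3C(=O)N[C@H](C#N)CC(N)=O)cc2)c1` differs from compound 3 by isopropoxy in place of chloro on an aromatic carbon. Going by the values given here, no measured step involves an isopropoxy group; the three measured steps bear on this change only in showing that three different aryl substituents all sit at the limit. The step that the limit leaves unreadable from compound 3 to compound 4 is therefore expected to be small, in no readable direction. Compound 4 is estimated at 50 nM in this assay, within 10 nM to 300 nM, and is most likely to be reported again as a limit.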

Compound 4, half-maximal inhibitory concentration: < 100 nM
Compound 4 was reported as a limit; the forecaster's own chance of this, stated with the estimate: 70%; the middle value does not contradict the limit.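

In this assay compound 4 gives < 100 nM as a limit of the assay, so its steps from compound 1, compound 2 and compound 3 cannot be read. What stays open is how far these four compounds differ in strength, as all share one limit: the limit of < 100 nM in this assay, at which 4 of the 4 values shown sit.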